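The source may report more compounds than this note shows. Statements on the series, on what has been measured and on what is new or still open speak of the compounds shown alone.

Two members of the series carry a number in a functional assay on MCF7 cells (Homo sapiens) for cytotoxicity, read by sulforhodamine B assay, with a stated time of 2 days; a higher number here means a weaker inhibitor, a lower number a stronger inhibitor. Compound 1 `OC1CNCc2nc(-c3ccc(N4CCCC4)cc3)sc21` gives 1530 nM. Compound 2 `CN(C)c1ccc(-c2nc3c(s2)C(O)CNC3)c(CO)c1` gives 31 nM, the lowest of the two numbers and beyond the scatter from compound 1; the two structures differ in more than one place, so that gap is read only as what the two values show. Compound 3 `OCc1cc(N2CCCC2)ccc1-c1nc2c(s1)C(O)CNC2` has not been measured in this assay. It differs from compound 2 by pyrrolidin-1-yl in place of dimethylamino on an aromatic carbon, with the hydroxymethyl group of compound 2 kept. Within the data shown here, no measured pair isolates this exchange, so its size is open; a step within the scatter, in either direction, is expected. For compound 3 the estimated value is 40 nM, with a range of 10 nM to 160 nM. The expected step is a 1.3-fold higher number from compound 2 to compound 3 (0.11 log units; within the scatter).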

Compound 3, half-maximal inhibitory concentration: 13 nM
For compound 3 the middle estimate is 3.1-fold (0.49 log units) above the measured one; low and high end bracket the measured number.
By their numbers in this assay, from the lowest: compound 3; then compound 2; then compound 1.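

In this assay the exchange of dimethylamino for pyrrolidin-1-yl on this aromatic carbon, with the hydroxymethyl group kept, now has an isolated reading: a 2.4-fold lower number from compound 2 to compound 3 (0.38 log units; beyond the scatter) is a modest step, so this position tolerates the larger five-membered ring in these compounds. The hydroxymethyl group marks the much bigger change, with a 120-fold lower number from compound 1 to compound 3 (2.07 log units; beyond the scatter) for the same pyrrolidin-1-yl compound carrying hydrogen in its place. Compound 3 thus links compound 1 and compound 2 through single changes, which their direct comparison could not do.

Still open, on these data alone, is whether either step keeps its size with the other group changed, and how piperidin-1-yl or morpholin-4-yl on this carbon, or hydroxyethyl in place of hydroxymethyl, would read. Nothing at hand gives a reason for either step.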